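This account rests on a few compounds, and the source may have more. Where it says the series, first, only, none or still open, it means among the compounds named here.

The compounds share a core, seen in compound 1 `CCc1ccc(Cn2cncc2CNc2ccc(-c3nc4ccccc4s3)c(-c3ccccc3)c2)cc1`, and each is examined in a toxicity assay on NIH3T3 cells (Mus musculus) for cytotoxicity, read by resazurin assay; a lower number here means that less compound is needed, a higher number that more compound is needed for the effect. Compound 1 does not yield a number there: its value of > 1000 nM is a limit of the assay, meaning the effect was not reached within the tested range. Compound 2 `Cc1cccc(-c2cc(NCc3cncn3Cc3ccc(-c4ccccc4)cc3)ccc2-c2nc3ccccc3s2)c1C` stands at the same limit, with > 1000 nM. Compound 3 `O=[N+]([O-])c1ccc(Cn2cncc2CNc2cccc(-c3ccccc3)c2)cc1`, which differs from the other two in more than one place, does give a number, 10000 nM. So two of the three values rest at the limit of > 1000 nM in this assay, at which 2 of the 3 values shown sit, and no pair of measured compounds differs in only one place, which means no single-change step has yet been measured in this series.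

The next compound, compound 4 `CS(=O)(=O)c1ccc(Cn2cncc2CNc2ccc(-c3nc4ccccc4s3)c(-c3ccccc3)c2)cc1`, differs from compound 1 in a single place: methylsulfonyl in place of ethyl on an aromatic carbon. With compound 1 known only as a limit, the step expected from compound 1 to compound 4 in this assay, a step that the limit leaves unreadable from compound 1 to compound 4, is one of no change beyond the usual scatter, in either direction. Compound 4 is therefore estimated at 5000 nM, with a range from 1500 nM to 20000 nM, and it is expected that this assay will most likely again report only a limit for compound 4.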

Compound 4, half-maximal effective concentration: > 1000 nM
Compound 4: no number, only a limit; the forecaster's own chance of this, stated with the estimate: 70%; the middle value does not contradict the limit.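

In this assay compound 4 gives > 1000 nM, which is a limit and not a number. Compound 1 also has only a limit, and no step can be read between compound 1 and compound 4. The compounds shown leave open the actual values of compound 1, compound 2 and compound 4, and whether methylsulfonyl in place of ethyl changes anything in this assay: the limit of > 1000 nM in this assay, at which 3 of the 4 values shown sit.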